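Acetylation of a Secondary Hydroxyl in a Cytotoxic Series

A few compounds are considered here, and "the series" means these few. Any claim that something is new, unique, unknown or untested is made for them only; others in the source may bear on it.

Of the compounds shown here, three of one series have so far been tested in a functional assay on MDA-MB-231 cells (Homo sapiens) for cytotoxicity, read by MTT assay; on this read-out higher numbers stand for weaker inhibition and lower numbers for stronger inhibition. Compound 1 `CC(=O)O[C@@H]1C[C@@H](OC(C)=O)C(C)(C)[C@H](O)[C@H]2O[C@@]3(C[C@H](C)[C@H](OC(=O)c4ccccc4)[C@@H]3/C=C/1C)[C@@H](OC(C)=O)[C@H]2C` returns only a limit of the assay, > 10000 nM, in this assay. Compound 2 `CC(=O)O[C@@H]1[C@H]2O[C@@]3(C[C@H](C)[C@H](OC(=O)c4ccccc4)[C@@H]3/C=C(\C)[C@H](OC(C)=O)C[C@@H](OC(C)=O)C1(C)C)[C@@H](OC(C)=O)[C@H]2C` likewise returns only a limit, > 10000 nM. Compound 3 `CC(=O)O[C@@H]1C[C@@H](O)C(C)(C)/C=C/[C@H](C)[C@H](OC(C)=O)[C@@]2(O)C[C@H](C)[C@H](OC(=O)c3ccccc3)[C@@H]2/C=C/1C` also gives nothing more than a limit, > 10000 nM. Going by the values given here, the single step between measured neighbours, a step that the two limits leave unreadable from compound 1 to compound 2, cannot be sized because both of its ends rest on (the limit of > 10000 nM in this assay, at which 3 of the 3 values shown sit). Compound 4 `CC(=O)O[C@@H]1C[C@@H](OC(C)=O)C(C)(C)/C=C/[C@H](C)[C@H](OC(C)=O)[C@@]2(O)C[C@H](C)[C@H](OC(=O)c3ccccc3)[C@@H]2/C=C/1C` has not yet been measured; it differs from compound 3 by acetyl in place of hydrogen on an oxygen on a saturated carbon, the same kind of change as that unreadable measured step. Among the compounds with values here, since the only step that bears on it gives no readable size or direction, no shift beyond the usual scatter can be expected. Compound 4 is therefore expected to sit near 15000 nM, within a range of 5000 nM to 50000 nM, most likely as another limit. The expected step that the limit leaves unreadable from compound 3 to compound 4 is estimated to lie within the scatter.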

Compound 4, half-maximal inhibitory concentration: 13400 nM
The estimate for compound 4 lay 1.1-fold (0.05 log units) above the measured number; the measured number falls inside the stated range.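

No step can be read from compound 3 to compound 4, because compound 3 gives only a limit: the limit of > 10000 nM in this assay, at which 3 of the 4 values shown sit.

The compounds shown leave open whether hydroxy to acetoxy at this place shifts the result in this assay at all, and in which direction.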